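The compounds below may be only part of what the source reports. "The series", "measured", "known", "first", "only" and "open" are said of these compounds alone.

Compound 1 `O=S(=O)(NCCCNCc1ccccc1Cl)c1cc(C(F)(F)F)cc(C(F)(F)F)c1`: 10000 nM
Compound 2 `O=S(=O)(NCCCNCc1ccc(Cl)c(C(F)(F)F)c1)c1cc(C(F)(F)F)cc(C(F)(F)F)c1`: 3000 nM

In a functional assay on HPAC cells (Homo sapiens) for inhibition, read by MTT assay, with a stated time of 72 h (on this read-out higher numbers stand for weaker inhibition of growth and lower numbers for stronger inhibition of growth), compound 2 gives 3000 nM, the lower of the two numbers shown, while compound 1 gives 10000 nM. Compound 3 `O=S(=O)(NCCCNCC1COc2ccccc2O1)c1cc(C(F)(F)F)cc(C(F)(F)F)c1` differs from compound 2 by 2,3-dihydro-1,4-benzodioxin-2-yl in place of 4-chloro-3-(trifluoromethyl)phenyl on a saturated chain carbon bound to an amine nitrogen. For the measured compounds named here, the only measured step at this position is a 3.3-fold lower number from compound 1 to compound 2 (0.52 log units; beyond the scatter), which shows that changing the group on this carbon can move the number beyond the scatter. Going by the values given here, no measured step covers the 2,3-dihydro-1,4-benzodioxin-2-yl group, so the direction is uncertain. Compound 3 is expected to give a somewhat higher number, a 2.0-fold higher number from compound 2 to compound 3 (0.30 log units; within the scatter). The estimate for compound 3 is 6000 nM, with a range from 2000 nM to 20000 nM.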

Compound 3, concentration for 50% growth inhibition: 2700 nM
Compound 3: middle estimate off by 2.2-fold (0.35 log units), on the high side, and the stated range covers the measured number.
By their numbers in this assay, from the lowest: compounds 3 and 2 (each within the scatter of the next); then compound 1.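

In this assay, the swap on the saturated chain carbon bound to an amine nitrogen gives a 1.1-fold lower number from compound 2 to compound 3 (0.05 log units; within the scatter), so 2,3-dihydro-1,4-benzodioxin-2-yl, with oxygen and no halogen, serves here as well as 4-chloro-3-(trifluoromethyl)phenyl. Against 2-chlorophenyl the same group gives a 3.7-fold lower number from compound 1 to compound 3 (0.57 log units; beyond the scatter), so the lower numbers at this position do not require chlorine on the group. Nothing available explains these numbers. As far as these compounds go, whether a simple amine or a carboxylic acid on this carbon would keep such numbers remains open, as does the effect of a longer chain.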